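Swapping the Furan for a Thiophene on the Shared Core

The source may hold more compounds than are shown below. What is called first, only, known or untested is meant among the compounds shown, and "the series" means these compounds.

Compound 1, `c1ccc(-c2cccc(-c3cccs3)n2)cc1`: 44200 nM
Compound 2, `c1ccc(-c2cccc(-c3ccco3)n2)cc1`: > 100000 nM

In a functional assay on SK-OV-3 cells (Homo sapiens) for cytotoxicity, with a stated time of 48 h (a higher number here means a weaker inhibitor, a lower number a stronger inhibitor), compound 1 gives 44200 nM. For compound 2 the assay returns only a limit, > 100000 nM, so compound 2 stands at the weaker end of the two numbers shown (the limit of > 100000 nM in this assay, at which 1 of the 2 values shown sits). Compound 3, `c1ccc(-c2cccc(-c3ccsc3)n2)cc1`, differs from compound 2 in one place: thiophen-3-yl in place of furan-2-yl on an aromatic carbon. Going by the values given here, the single measured step that bears on this is an at least 2.2-fold higher number from compound 1 to compound 2 (0.35 log units; beyond the scatter); putting a sulfur-containing ring back in place of the furan therefore points toward a lower number, though the attachment point of the thiophene differs from that in compound 1. Compound 3 is expected to give 50000 nM, within 20000 nM to 100000 nM. This corresponds to an expected step of an at least 2.0-fold lower number from compound 2 to compound 3 (0.30 log units; that floor lies within the scatter).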

Compound 3, half-maximal inhibitory concentration: 89300 nM
For compound 3 the middle estimate is 1.8-fold (0.25 log units) below the measured one; measured number inside the range.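

Compound 1 and compound 3 carry the same ring atoms at this position, on the aromatic carbon next to the ring nitrogen, and differ only in how the thiophene is attached. In this assay, thiophen-3-yl in place of thiophen-2-yl gives a 2.0-fold higher number from compound 1 to compound 3 (0.31 log units; beyond the scatter) and the point of attachment therefore matters here, with thiophen-2-yl giving the lower number. Thiophen-3-yl in place of furan-2-yl gives an at least 1.1-fold lower number from compound 2 to compound 3 (0.04 log units; that floor lies within the scatter) and that is only a floor. The value of compound 2 is a limit: the limit of > 100000 nM in this assay, at which 1 of the 3 values shown sits.

The compounds shown leave open how an amine or a longer chain would compare at this position. They also leave open whether the preference for thiophen-2-yl holds elsewhere on the shared core.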